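The source may hold more compounds than are shown below. What is called first, only, known or untested is meant among the compounds shown, and "the series" means these compounds.

Compound 1 `CCCc1n[nH]c2c(=O)n(NC(=O)c3ccccc3)c(-c3cccc([N+](=O)[O-])c3)nc12` sets the reference point of this small series. In a functional assay on SK-OV-3 cells (Homo sapiens) for cytotoxicity, read by sulforhodamine B assay, with a stated time of 2 days, tested at 100 uM (on this read-out higher numbers stand for more inhibition at the one concentration tested (going by the name of the read-out) and lower numbers for less inhibition), compound 1 gives 28.8%. Compound 2 `CCCc1n[nH]c2c(=O)n(NC(=O)c3ccccc3)c(-c3cccc(OC)c3)nc12` differs from it by a single exchange on the phenyl ring, (methoxy in place of nitro on an aromatic carbon), and in this assay compound 2 gives 9.96%; the step of a number 18.8 percentage points lower from compound 1 to compound 2 (beyond the scatter) is therefore a clear fall. Compound 3 `O=C(Nn1c(-c2cccc([N+](=O)[O-])c2)nc2c(-c3ccco3)n[nH]c2c1=O)c1ccccc1` keeps the nitro group but carries a different substituent on the shared core, (furan-2-yl in place of propyl on an aromatic carbon); in this assay compound 3 gives 17.9%, and the step of a number 10.9 percentage points lower from compound 1 to compound 3 (beyond the scatter) is likewise a fall. Compound 4 `COc1cccc(-c2nc3c(-c4ccco4)n[nH]c3c(=O)n2NC(=O)c2ccccc2)c1` takes the core of compound 3 and repeats the exchange already seen between compound 1 and compound 2, (methoxy in place of nitro on an aromatic carbon), at the same place on the phenyl ring, so it is the same change. Compound 4 is expected to lose inhibition by a number 13.9 percentage points lower from compound 3 to compound 4 (beyond the scatter), a step resting on the fall a number 18.8 percentage points lower from compound 1 to compound 2 (beyond the scatter) and on the lower starting point of compound 3 at 17.9%. The estimate for compound 4 in this assay is 4%, bounded by -8% and 15%.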

Compound 4, a percentage reported as inhibition, at one concentration (the size of the read-out at that concentration, not a potency): 35.2%
Beside the measured number, compound 4's estimate is 31.2 percentage points below it; measured number above the stated range.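

In this assay, the exchange of nitro for methoxy does not carry from one core to the other: with the furan-2-yl group on the shared core it gives a number 17.3 percentage points higher from compound 3 to compound 4 (beyond the scatter), the opposite direction to the fall seen with propyl on the core, and the two steps differ clearly: the same change on two cores in this assay, a number 18.8 percentage points lower (beyond the scatter) from compound 1 to compound 2 and a number 17.3 percentage points higher (beyond the scatter) from compound 3 to compound 4, 36.1 percentage points apart, beyond the scatter of two such steps
The other exchange behaves in the same way, since furan-2-yl in place of propyl gives a number 25.2 percentage points higher from compound 2 to compound 4 (beyond the scatter) with methoxy on the phenyl ring, against a fall with nitro there: the same change on two cores in this assay, a number 10.9 percentage points lower (beyond the scatter) from compound 1 to compound 3 and a number 25.2 percentage points higher (beyond the scatter) from compound 2 to compound 4, 36.1 percentage points apart, beyond the scatter of two such steps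
So, within these four compounds, the effect of each exchange depends on the group at the other place, but this single set of four does not show why, nor does a read-out at one concentration show any change in potency.

From the compounds shown here alone, it remains open whether the reversal would recur with an amine or a carboxylic acid on the phenyl ring, or with a longer chain in place of propyl. Whether it extends to other cell lines also stays unresolved here.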